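The compounds below may be only part of what the source reports. "The series", "measured", "known", "first", "only" and "open" are said of these compounds alone.

In a functional assay on HCT-116 cells (Homo sapiens) for cytotoxicity, read by MTT assay, with a stated time of 72 h (a higher number here means a weaker inhibitor, a lower number a stronger inhibitor), compound 1 `Cc1ccc(S(=O)(=O)n2cc(COC3=C/C(=N\c4ccc(I)cc4)c4ccccc4C3=O)nn2)cc1` reads > 16300 nM, which is a limit and not a number. Going by the values given here, compound 2 `Cc1ccc(S(=O)(=O)n2cc(COC3=C/C(=N\c4ccc(Br)cc4)c4ccccc4C3=O)nn2)cc1` gives 9250 nM, the only true number so far. Compound 3 `Cc1ccc(S(=O)(=O)n2cc(COC3=C/C(=N\c4ccc(F)cc4)c4ccccc4C3=O)nn2)cc1` differs from compound 2 in one place: fluoro in place of bromo on an aromatic carbon. Among the compounds with values here, the only measured step bearing on this is an at least 1.7-fold lower number from compound 1 to compound 2 (0.24 log units; that floor lies within the scatter), and it is a floor, so it sets no firm size or direction. A change within the scatter is therefore expected in this assay, and the estimated step is a 1.1-fold lower number from compound 2 to compound 3 (0.04 log units; within the scatter). Compound 3 is estimated at 8500 nM, with an expected range from 3500 nM to 20000 nM.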

Compound 3, half-maximal inhibitory concentration: 5750 nM
The estimate for compound 3 lay 1.5-fold (0.17 log units) above the measured number; low and high end bracket the measured number.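

In this assay, the halogens at this position give their first step beyond the scatter, going from iodo to fluoro (an at least 2.8-fold lower number from compound 1 to compound 3 (0.45 log units; beyond the scatter)). Fluoro in place of bromo alone stays within the scatter (a 1.6-fold lower number from compound 2 to compound 3 (0.21 log units; within the scatter)), so compound 2 and compound 3 cannot be ranked. The larger step is only a floor, since compound 1 carries a limit and not a number: the limit of > 16300 nM in this assay, at which 1 of the 3 values shown sits.

The compounds shown hold only halogens on this carbon. Going by these compounds, how an amine or a carboxylic acid there would read stays open.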